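A Chlorine on the Benzyl Arm of Compound 3

This account rests on a few compounds, and the source may have more. Where it says the series, first, only, none or still open, it means among the compounds named here.

Of the compounds shown here, three sharing one core have been tested in an in vitro functional assay on HEK285-7 cells for antagonist activity at prostaglandin D2 receptor 2 (Homo sapiens), read by BRET and beta-arrestin recruitment; on this read-out higher numbers stand for weaker inhibition and lower numbers for stronger inhibition. Compound 1 `COc1ccccc1Nc1nc(-c2ccc(Cl)cc2)c(CC(=O)O)s1` gives 730 nM in this assay. Compound 2 `O=C(O)Cc1sc(-c2ccccc2)nc1-c1ccc(-c2ccccc2)cc1` gives 38 nM. Compound 3 `O=C(O)Cc1sc(Cc2ccccc2)nc1-c1ccc(Cl)cc1` gives 4100 nM, the highest number of the three, so it is the weakest inhibitor here: its distance to compound 1 and its distance to compound 2 both lie beyond the usual scatter of repeated measurements.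

Compound 4 `O=C(O)Cc1sc(Cc2ccc(Cl)cc2)nc1-c1ccc(Cl)cc1` has not yet been measured. It differs from compound 3 in one place: chloro in place of hydrogen on an aromatic carbon. For the measured compounds named here, nothing among the measured compounds isolates this exact change, so no measured step can guide the expectation directly. The single chlorine is a small addition, and small additions on an outer ring usually move the number only modestly. Compound 4 is therefore expected to stay near compound 3, with the chance of a slight gain in inhibition, giving an estimated step of a 2.3-fold lower number from compound 3 to compound 4 (0.36 log units; beyond the scatter). The estimate for compound 4 in this assay is 1800 nM, with a range from 600 nM to 5000 nM; a result within the scatter of compound 3 would not be surprising.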

Compound 4, half-maximal inhibitory concentration: 220 nM
Estimate against measurement, compound 4: 8.2-fold (0.91 log units) above; measured number outside the range, below it.
By their numbers in this assay, from the lowest: compound 2; then compound 4; then compound 1; then compound 3.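

In this assay, changing the benzyl arm of compound 3 to the 4-chlorobenzyl arm gives a 19-fold lower number from compound 3 to compound 4 (1.27 log units; beyond the scatter), so this outer position responds strongly to the addition of one chlorine atom. For the compounds shown here, none of the earlier compounds differed from one another in only one place, so this pair gives the first direct reading of a single change, here on the six-membered aromatic ring of the benzyl arm, para to a large group. No measurement available here explains why this chlorine has so large an effect.

The compounds shown offer only chloro at this position, so they leave open whether fluoro, methyl or an amine in the same place would produce a step of similar size. They also leave open whether the gain would persist if a longer chain replaced the single carbon linking the 4-chlorophenyl ring to the shared core.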